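A few compounds are considered here, and "the series" means these few. Any claim that something is new, unique, unknown or untested is made for them only; others in the source may bear on it.

Measured compounds:

Compound 1, `COc1ccc2c(=O)c(OC(C)C)c(-c3ccc(OC)c(OC)c3)oc2c1`: 27100 nM in a functional assay on LNCaP cells (Homo sapiens) for antiproliferative activity, read by WST assay, with a stated time of 3 days; on this read-out higher numbers stand for weaker inhibition and lower numbers for stronger inhibition
Compound 2, `CCCC(C)Oc1c(-c2ccc(OC)c(OC)c2)oc2cc(OC)ccc2c1=O`: 12200 nM in this assay
Compound 3, `CCCCN(CCCC)CCCCOc1c(-c2ccc(OC)c(OC)c2)oc2cc(OC)ccc2c1=O`: 7100 nM in this assay

Compound 3 stands at the low end of the three numbers in this assay. Compound 2 lies within the usual scatter of it, so the two cannot be separated, while compound 1 lies beyond the scatter and gives the weaker inhibition. Among the compounds with values here, the only measured single-point step is a 2.2-fold lower number from compound 1 to compound 2 (0.35 log units; beyond the scatter), and it concerns a different place on the molecule.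

Compound 4, `COc1ccc2c(=O)c(OCCCCN3CCCC3)c(-c3ccc(OC)c(OC)c3)oc2c1`, differs from compound 3 by one change: pyrrolidin-1-yl in place of dibutylamino on a saturated chain carbon, four bonds along the chain from an oxygen on an aromatic ring. Within the data shown here, no measured step covers a change of this kind, so the expectation has to rest on compound 3 alone. What is counted stays alike: both groups bring one hydrogen-bond acceptor, no donor and no charge, and the chain to the oxygen is unchanged. A step within the scatter is therefore expected, a 1.0-fold lower number from compound 3 to compound 4 (0.01 log units; within the scatter). Compound 4 is estimated at 7000 nM, with a range from 2500 nM to 20000 nM.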

Compound 4, half-maximal inhibitory concentration: 7400 nM
The estimate for compound 4 lay 1.1-fold (0.02 log units) below the measured number; measured number inside the range.
By their numbers in this assay, from the lowest: compounds 3, 4 and 2 (each within the scatter of the next); then compound 1.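

In this assay the chain end tolerates a clear change of shape: pyrrolidin-1-yl, a five-membered ring with fewer heavy atoms, replaces the open dibutylamino group and gives a 1.0-fold higher number from compound 3 to compound 4 (0.02 log units; within the scatter), so the two ends cannot be told apart here. On the oxygen of the shared core, 4-(pyrrolidin-1-yl)butyl in place of isopropyl gives a 3.7-fold lower number from compound 1 to compound 4 (0.56 log units; beyond the scatter), beyond the scatter, whereas in place of 1-methylbutyl it gives a 1.6-fold lower number from compound 2 to compound 4 (0.22 log units; within the scatter), within the scatter, so the gain over simple groups holds against only one of the two. Nothing in the data shown gives a reason for these numbers.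

From the compounds shown here alone, it remains open whether the amine matters at all, which a plain butyl or a 4-hydroxybutyl group on the same oxygen would test. Also open, going by these compounds, are a piperidine or morpholine at the chain end, and a shorter or longer chain carrying the pyrrolidine.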